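Swapping the Methoxy for Nitro on the Amide Ring

The compounds below may be only part of what the source reports. "The series", "measured", "known", "first", "only" and "open" are said of these compounds alone.

Of the compounds shown here, three sharing one core have been measured in a functional assay on HepG2 cells (Homo sapiens) for antiproliferative activity, read by CCK-8 assay, with a stated time of 72 h; on this read-out higher numbers stand for weaker inhibition and lower numbers for stronger inhibition. Compound 1 `COc1ccc(C(=O)Nc2cccc(-c3oc4cc(-c5ccc(F)cc5)ccc4c(=O)c3O)c2)cc1` gives 8420 nM and stands highest of the three numbers. Compound 2 `Cc1ccc(C(=O)Nc2cccc(-c3oc4cc(-c5ccc(F)cc5)ccc4c(=O)c3O)c2)cc1` gives 2320 nM, and compound 3 `O=C(Nc1cccc(-c2oc3cc(-c4ccc(F)cc4)ccc3c(=O)c2O)c1)c1cc(F)cc(F)c1` gives 4960 nM. Among the measured compounds shown here, the step of a 3.6-fold lower number from compound 1 to compound 2 (0.56 log units; beyond the scatter) is the only change that moved the number beyond the scatter, while a 1.7-fold lower number from compound 1 to compound 3 (0.23 log units; within the scatter) and a 2.1-fold higher number from compound 2 to compound 3 (0.33 log units; beyond the scatter) describe the smaller remaining differences.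

Compound 4 `O=C(Nc1cccc(-c2oc3cc(-c4ccc(F)cc4)ccc3c(=O)c2O)c1)c1ccc([N+](=O)[O-])cc1` has not yet been tested. Its difference from compound 1 is nitro in place of methoxy on an aromatic carbon. For the measured compounds named here, no measured pair shows a nitro group, so the closest guides are the two departures from the methoxy of compound 1, both of which gave lower numbers: the step of a 3.6-fold lower number from compound 1 to compound 2 (0.56 log units; beyond the scatter) and the smaller 1.7-fold lower number from compound 1 to compound 3 (0.23 log units; within the scatter). A modest lowering is therefore expected, though with wide uncertainty. For compound 4 the estimate in this assay is 4200 nM, within a range of 1500 nM to 12000 nM, which corresponds to an expected step of a 2.0-fold lower number from compound 1 to compound 4 (0.30 log units; within the scatter).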

Compound 4, half-maximal inhibitory concentration: 1860 nM
For compound 4 the middle estimate is 2.3-fold (0.35 log units) above the measured one; the measured number falls inside the stated range.
By their numbers in this assay, from the lowest: compounds 4 and 2 (each within the scatter of the next); then compounds 3 and 1 (each within the scatter of the next).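

Methyl is not the only replacement for methoxy at this position, para to a large group, that moves the number beyond the scatter: nitro does so too, with a 4.5-fold lower number from compound 1 to compound 4 (0.66 log units; beyond the scatter). Nitro and methyl cannot be told apart here, given a 1.2-fold lower number from compound 2 to compound 4 (0.10 log units; within the scatter), so two quite different groups land at the same level, while the 4-nitrophenyl amide also separates from the 3,5-difluorophenyl amide, with a 2.7-fold lower number from compound 3 to compound 4 (0.43 log units; beyond the scatter). Nothing available explains why these changes shift the numbers as they do.

The compounds shown leave open how an amine or a carboxylic acid would read at this same place. They also leave open whether nitro would give a similar number at another carbon of this ring.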